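Hydroxy for methoxy on the bis-trifluoromethyl urea

The source may hold more compounds than are shown below. What is called first, only, known or untested is meant among the compounds shown, and "the series" means these compounds.

Among the measured compounds shown here, compound 2 `COc1cc(-c2nn(-c3cccc(NC(=O)Nc4cc(C(F)(F)F)cc(C(F)(F)F)c4)c3)cc2-c2ccncc2)ccc1Cl` gives 694 nM in a functional assay on SK-MEL-5 cells (Homo sapiens) for inhibition, read by sulforhodamine B assay, with a stated time of 48 h (a lower number here means a stronger inhibitor of growth, a higher number a weaker inhibitor of growth), the lowest of the three numbers measured so far, though its distances to compound 3 `COc1cc(-c2nn(-c3cccc(NC(=O)Nc4cccc(C(F)(F)F)c4)c3)cc2-c2ccncc2)ccc1Cl`, which gives 720 nM, and to compound 1 `O=C(Nc1cccc(-n2cc(-c3ccncc3)c(-c3ccc(Cl)c(O)c3)n2)c1)Nc1cccc(C(F)(F)F)c1`, which gives 1300 nM, both lie within the scatter, so no order among the three can be claimed. The step to compound 4 `O=C(Nc1cccc(-n2cc(-c3ccncc3)c(-c3ccc(Cl)c(O)c3)n2)c1)Nc1cc(C(F)(F)F)cc(C(F)(F)F)c1` is hydrogen in place of methyl on an oxygen on an aromatic ring. For the measured compounds named here, one measured step bears on it directly, run in the opposite direction: a 1.8-fold lower number from compound 1 to compound 3 (0.26 log units; within the scatter). The other, a 1.0-fold higher number from compound 2 to compound 3 (0.02 log units; within the scatter), shows that one trifluoromethyl more or less leaves this assay unchanged, so the methyl-to-hydrogen exchange seen between compound 1 and compound 3 should carry over to the pair carrying two trifluoromethyl groups. Compound 4 is therefore expected to give a somewhat higher number, a 1.7-fold higher number from compound 2 to compound 4 (0.24 log units; within the scatter), a step that stays within the scatter. The estimate for compound 4 is 1200 nM, with a range from 500 nM to 3000 nM.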

Compound 4, concentration for 50% growth inhibition: 600 nM
Compound 4: middle estimate off by 2.0-fold (0.30 log units), on the high side; the range from low to high includes it.
By their numbers in this assay, from the lowest: compounds 4, 2, 3 and 1 (each within the scatter of the next, the first and the last beyond it).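

In this assay, methoxy to hydroxy on the compound carrying two trifluoromethyl groups reads a 1.2-fold lower number from compound 2 to compound 4 (0.06 log units; within the scatter), and the change cannot be said to act differently on the two cores: the same change on two cores in this assay, a 1.8-fold lower number (0.26 log units; within the scatter) from compound 1 to compound 3 and a 1.2-fold higher number (0.06 log units; within the scatter) from compound 4 to compound 2, 2.1-fold (0.32 log units) apart, within the scatter of two such steps. Trifluoromethyl in place of hydrogen on the hydroxy core gives the only step so far beyond the scatter, a 2.2-fold lower number from compound 1 to compound 4 (0.34 log units; beyond the scatter), but this does not establish that the added trifluoromethyl counts only when hydroxy is present: the same change on two cores in this assay, a 1.0-fold higher number (0.02 log units; within the scatter) from compound 2 to compound 3 and a 2.2-fold higher number (0.34 log units; beyond the scatter) from compound 4 to compound 1, 2.1-fold (0.32 log units) apart, within the scatter of two such steps.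

On this oxygen, only hydrogen and methyl are shown, and they do not separate on either core. From the compounds shown here alone, whether an ethyl, an aminoethyl chain or a chain ending in a carboxylic acid on that oxygen, or an amine in place of the hydroxy, would move the number remains open.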